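The compounds below may be only part of what the source reports. "The series", "measured", "known", "first", "only" and "open" are said of these compounds alone.

Measured in an ADME assay on HCT-116 cells (Homo sapiens) for cytotoxicity, read by CellTiter-Glo, with a stated time of 72 h; on this read-out lower numbers stand for stronger inhibition and higher numbers for weaker inhibition:
compound 1 `COc1ccc(-c2cccc(S(=O)(=O)N3CCC(N4CCC(C)CC4)CC3)c2)cc1`: > 5000 nM, a limit
compound 2 `CC1CCN(C2CCN(S(=O)(=O)c3cccc(-c4ccc(F)cc4)c3)CC2)CC1`: > 5000 nM, a limit
compound 3 `COc1cccc(S(=O)(=O)N2CCC(N3CCC(C)CC3)CC2)c1`: > 5000 nM, a limit

Compound 3 gives > 5000 nM, which is a limit and not a number. It has no readable rank among the three, for the series shows only (the limit of > 5000 nM in this assay, at which 3 of the 3 values shown sit).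

The next compound, compound 4 `CC1CCN(C2CCN(S(=O)(=O)c3cccc(-c4ccccc4)c3)CC2)CC1`, differs from compound 3 by one change, phenyl in place of methoxy on an aromatic carbon.

The nearest measured changes are a step that the two limits leave unreadable from compound 1 to compound 3 and a step that the two limits leave unreadable from compound 2 to compound 3. Both exchange methoxy and a substituted phenyl at an aromatic carbon, in the opposite direction to the change considered here. The related step that the two limits leave unreadable from compound 1 to compound 2 gives no size either. No measured size can therefore be carried over, and no step beyond the scatter is expected in this assay, in either direction.

The expected outcome is a step that the limit leaves unreadable from compound 3 to compound 4.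

For compound 4 the estimated value is 8000 nM, with an expected range from 3000 nM to 20000 nM.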

Compound 4, half-maximal inhibitory concentration: > 5000 nM
Compound 4 gave a limit, no number (the forecaster's own chance of this, stated with the estimate: 85%); the middle value does not contradict the limit.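

Compound 4 gives > 5000 nM as a limit and not a number. Within the data shown here, no step between compound 4 and compound 1, compound 2 or compound 3 can be read. The compounds shown leave open whether methoxy, phenyl, 4-fluorophenyl or 4-methoxyphenyl differ at all in this read-out.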